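Replacing a basic side chain with an oxygen-linked ring

A few compounds are considered here, and "the series" means these few. Any claim that something is new, unique, unknown or untested is made for them only; others in the source may bear on it.

Measured so far:
- compound 1 `CN(C)CCCNc1ccc(S(=O)(=O)NC(=O)c2ccc(N3CCN(CC4=C(c5ccc(C(F)(F)F)cc5)CC(C)(C)CC4)CC3)cc2Oc2cnc3[nH]ccc3c2)cc1[N+](=O)[O-]`: 3.9 nM
- compound 2 `CC1(C)CCC(CN2CCN(c3ccc(C(=O)NS(=O)(=O)c4ccc(NCC5CCOC5)c([N+](=O)[O-])c4)c(Oc4cnc5[nH]ccc5c4)c3)CC2)=C(c2ccc(C(F)(F)F)cc2)C1`: 24.2 nM

In a functional assay on RS4-11 cells (Homo sapiens) for inhibition, read by CCK-8 assay, with a stated time of 72 h (on this read-out higher numbers stand for weaker inhibition and lower numbers for stronger inhibition), compound 1 gives 3.9 nM, the lowest of the two numbers; its nearest neighbour is compound 2 at 24.2 nM, separated by a 6.2-fold higher number from compound 1 to compound 2 (0.79 log units; beyond the scatter). Compound 3 `CC(Oc1ccc(S(=O)(=O)NC(=O)c2ccc(N3CCN(CC4=C(c5ccc(C(F)(F)F)cc5)CC(C)(C)CC4)CC3)cc2Oc2cnc3[nH]ccc3c2)cc1[N+](=O)[O-])C1CCOCC1` is not yet measured. It differs from compound 1 by a group of 9 heavy atoms (7 carbon, 2 oxygen; one six-membered non-aromatic ring with 1 hetero atom) in place of a group of 7 heavy atoms (5 carbon, 2 nitrogen; no ring), on an aromatic carbon. Among the compounds with values here, the only measured step that bears on this is the one from compound 1 to compound 2, where a chain carrying a dimethylamino group gave way to a ring with one oxygen and the number rose by a 6.2-fold higher number from compound 1 to compound 2 (0.79 log units; beyond the scatter). Compound 3 likewise loses the dimethylamino chain and gains an oxygen-containing ring, so a weakening of similar size is expected, a 6.4-fold higher number from compound 1 to compound 3 (0.81 log units; beyond the scatter). For compound 3 the estimated value is 25 nM, with a range from 8 nM to 80 nM.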

Compound 3, half-maximal inhibitory concentration: 269 nM
Compound 3: middle estimate off by 11-fold (1.03 log units), on the low side; the whole stated range lies below it.
By their numbers in this assay, from the lowest: compound 1; then compound 2; then compound 3.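

In this assay, losing the (3-(dimethylamino)propyl)amino group does not carry one fixed cost, since the group entering this aromatic carbon matters: the exchange for the oxygen-containing six-membered ring gives a 69-fold higher number from compound 1 to compound 3 (1.84 log units; beyond the scatter). Both rings carry an oxygen, yet the step between them is still large, at an 11-fold higher number from compound 2 to compound 3 (1.05 log units; beyond the scatter), so an oxygen in the ring does not on its own set the number here; the group in compound 3 also has no nitrogen and no hydrogen-bond donor, unlike the group in compound 2. Nothing available explains why these groups differ so much.

The compounds shown leave open which difference between the groups in compound 2 and compound 3 counts most. A six-membered ring with one oxygen joined through an amine nitrogen would help separate the ring from the atom that links it.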